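From Compound 1 to Compound 3: Adding Acetamidomethyl

This account rests on a few compounds, and the source may have more. Where it says the series, first, only, none or still open, it means among the compounds named here.

Compound 1 `Cn1cc(C#N)c2ccc(Nc3ncc(-c4ccccc4)o3)cc21`: 8000 nM
Compound 2 `Cn1cc(C#N)c2ccc(Nc3ncc(-c4cccc(NC(=O)c5ccccc5)c4)o3)cc21`: 3500 nM

Within the data shown here, in a functional assay on CCRF-CEM cells (Homo sapiens) for inhibition (a lower number here means a stronger inhibitor, a higher number a weaker inhibitor), compound 1 gives 8000 nM, the higher of the two numbers measured so far, which makes it the weaker inhibitor of the pair. Among the measured compounds shown here, its only neighbour is compound 2, and the one measured step is a 2.3-fold lower number from compound 1 to compound 2 (0.36 log units; beyond the scatter). That step is modest and places benzamido in place of hydrogen on an aromatic carbon.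

The next compound is compound 3 `CC(=O)NCc1ccc(-c2cnc(Nc3ccc4c(C#N)cn(C)c4c3)o2)cc1`. Its difference from compound 1 is acetamidomethyl in place of hydrogen on an aromatic carbon of a six-membered aromatic ring of carbon only, para to a large group.

For the measured compounds named here, the benzamido step is the only guide, and it involves a different group, so it bears on this change only loosely. Going by the values given here, a small move toward a lower number in this assay is expected, no larger than that step and possibly not beyond the scatter. The expected change is a 1.8-fold lower number from compound 1 to compound 3 (0.25 log units; within the scatter). For compound 3 the estimated value is 4500 nM, with an expected range of 1500 nM to 12000 nM.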

Compound 3, half-maximal inhibitory concentration: > 10000 nM
Compound 3: no number, only a limit; the forecaster's own chance of this, stated with the estimate: 15%; middle value at least 2.2-fold (0.34 log units) from the limit.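

In this assay compound 3 gives > 10000 nM, which is a limit of the assay and not a number. Acetamidomethyl on the six-membered aromatic ring of carbon only, para to a large group, therefore brings no lower number, and the step reads an at least 1.2-fold higher number from compound 1 to compound 3 (0.09 log units; that floor lies within the scatter). The only earlier step, with benzamido, was a 2.3-fold lower number from compound 1 to compound 2 (0.36 log units; beyond the scatter), so compound 3 shows that a new group on this ring of compound 1 does not bring a lower number as such, while the true size of the new step stays hidden behind the ceiling of the measurement: the limit of > 10000 nM in this assay, at which 1 of the 3 values shown sits.

From the compounds shown here alone, how far the number of compound 3 really lies past that limit stays open, and with it whether the step from compound 1 goes beyond the scatter. Also open, going by these compounds, is whether a plain amine, a carboxylic acid or a longer chain in this same place, para to a large group, would move the number down, as benzamido did for compound 2, or up, as acetamidomethyl did for compound 3.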